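Notes on the sulfamate amide series: amine substituent change

This account rests on a few compounds, and the source may have more. Where it says the series, first, only, none or still open, it means among the compounds named here.

Compound 1 `NS(=O)(=O)Oc1ccc2c(c1)CN(C(=O)c1cccc(N3CCC(N4CCCCC4)CC3)c1)CC2` and compound 2 `NS(=O)(=O)Oc1ccc2c(c1)CN(C(=O)c1cccc(N(Cc3ccccc3)Cc3ccco3)c1)CC2` share one core and differ only in what is attached to the nitrogen on the aromatic ring. In an assay on HEK293 cells for inhibition of Steryl-sulfatase (Homo sapiens), tested at 0.1 uM (on this read-out lower numbers stand for a weaker effect and higher numbers for a stronger effect at the one concentration tested), compound 1 gives 0%, while compound 2 gives 27.5%, the higher of the two numbers and beyond the scatter. Compound 3 `CCCN(Cc1ccccc1)c1cccc(C(=O)N2CCc3ccc(OS(N)(=O)=O)cc3C2)c1` is not yet measured; it differs from compound 2 by ethyl in place of furan-2-yl on a saturated chain carbon bound to a nitrogen on an aromatic ring. Among the compounds with values here, no measured pair bears on this change, so only a small loss in this assay is expected, possibly within the scatter. Compound 3 is estimated at 18%, ranging 3% to 35%. A step of a number 9.5 percentage points lower from compound 2 to compound 3 (within the scatter) is expected.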

Compound 3, a percentage reported as inhibition, at one concentration (the size of the read-out at that concentration, not a potency): 23.1%
Compound 3: the middle estimate sits 5.1 percentage points below what was measured, and the stated range covers the measured number.
By their numbers in this assay, from the lowest: compound 1; then compounds 3 and 2 (each within the scatter of the next).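

Ethyl in place of furan-2-yl on a saturated chain carbon bound to a nitrogen on an aromatic ring gives a step of a number 4.4 percentage points lower from compound 2 to compound 3 (within the scatter) in this assay. At this place, then, the five-membered aromatic ring and its hydrogen-bond acceptor are not required for the read-out to stay within the scatter at the one concentration tested. Nothing available gives a reason for this result.

Still open, on these data alone, is how a longer chain, an amine or a carboxylic acid at this place would read. A single concentration also leaves the potency of compound 2 and compound 3 unresolved.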